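Series notes: a cyclic core and a phenyl replacement

The source may report more compounds than this note shows. Statements on the series, on what has been measured and on what is new or still open speak of the compounds shown alone.

The open-chain pair comes first. Compound 1 `CCC(C)C(NC(=O)NO)C(=O)NC1CCCCC1` gives 89000 nM in a functional assay on L1210 cells (Mus musculus) for inhibition; on this read-out higher numbers stand for weaker inhibition and lower numbers for stronger inhibition. Compound 2 `CCC(C)C(NC(=O)NO)C(=O)NC(c1ccccc1)c1ccccc1` gives 54000 nM in this assay. Compound 3 `CCC(C)C1NC(=O)N(C2CCCC2)C1=O` reaches only the limit of this assay, reported as > 200000 nM, and that is a limit and not a number. Where compound 3 stands among the values shown is given by the limit of > 200000 nM in this assay, at which 1 of the 3 values shown sits. Compound 4 `O=C1NC(c2ccccc2)C(=O)N1C1CCCC1` has not been measured. The change from compound 3 is phenyl in place of sec-butyl on a saturated ring carbon. Among the measured compounds shown here, no measured step between any two compounds is available, so the size of the change in this assay is open. The step that the limit leaves unreadable from compound 3 to compound 4 is expected to be none beyond the scatter. Compound 4 is therefore estimated at 250000 nM, within 80000 nM to 800000 nM, and a further limit rather than a number is the more likely outcome.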

Compound 4, half-maximal inhibitory concentration: > 200000 nM
Compound 4: a limit, no number; the forecaster's own chance of this, stated with the estimate: 80%; the middle value lies beyond the limit too.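

Compound 3 and compound 4 each end at a limit in this assay, not a number, so no step can be read between them: the limit of > 200000 nM in this assay, at which 2 of the 4 values shown sit.
From the compounds shown here alone, whether phenyl in place of sec-butyl on a saturated ring carbon changes inhibition at all remains open.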